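Working notes on compounds 1 to 3 in one binding assay

The compounds below may be only part of what the source reports. "The series", "measured", "known", "first", "only" and "open" are said of these compounds alone.

compound 1 `COc1cccc(NC(=O)N[C@@H]2C3CCN(CC3)[C@@H]2Cc2cccnc2)c1`: > 10000 nM, a limit of the assay
compound 2 `O=C(NCc1ccc(Br)cc1)N[C@@H]1C2CCN(CC2)[C@@H]1Cc1cccnc1`: > 10000 nM, a limit of the assay

In a binding assay on a protein complex for binding affinity to Neuronal acetylcholine receptor; alpha4/beta2 (Homo sapiens) (a lower number here means a stronger inhibitor, a higher number a weaker inhibitor), compound 1 gives > 10000 nM, which is a limit of the assay and not a number. In this assay compound 2 gives > 10000 nM, also a limit. The step that the two limits leave unreadable from compound 1 to compound 2 is therefore unreadable; both values sit at the limit of > 10000 nM in this assay, at which 2 of the 2 values shown sit. Compound 3 `O=C(N[C@@H]1C2CCN(CC2)[C@@H]1Cc1cccnc1)c1c[nH]c2ccccc12` differs from compound 2 by 1H-indol-3-yl in place of (4-bromobenzyl)amino on a carbonyl carbon. Among the measured compounds shown here, no measured step touches a change at the carbonyl carbon, so neither size nor direction can be read from the series, and a second result at the limit remains possible. Compound 3 is expected at 8000 nM, between 1000 nM and 30000 nM. The expected step, then, is an at least 1.2-fold lower number from compound 2 to compound 3 (0.09 log units; that floor lies within the scatter).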

Compound 3, inhibition constant: > 10000 nM
Compound 3 ended at the assay's limit (the forecaster's own chance of this, stated with the estimate: 55%); at least 1.2-fold (0.09 log units) between middle value and limit.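

Among the compounds shown here, compound 3 also gives a limit of the assay, so no step among compound 1, compound 2 and compound 3 can be read: the limit of > 10000 nM in this assay, at which 3 of the 3 values shown sit. The compounds shown leave open whether any change on the carbonyl carbon alters the result in this assay.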